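Swapping the Five-Membered Ring in Compound 3

The compounds below may be only part of what the source reports. "The series", "measured", "known", "first", "only" and "open" are said of these compounds alone.

Of the compounds shown here, three built on a shared core have been tested in a functional assay with Alpha-1A adrenergic receptor (Homo sapiens) as the target, read by calcium flux; a higher number here means a larger maximal response, a lower number a smaller maximal response. Compound 1 `Cc1nc(-c2ccccc2NCC2=NCCN2)n(C)n1` gives 98%. Compound 2 `CCn1ncnc1-c1ccccc1NCC1=NCCN1` gives 107%. Compound 3 `Cc1n[nH]c(-c2ccccc2NCC2=NCCN2)n1` gives 87%, the lowest of the three numbers, with compound 1 nearest and compound 2 furthest, both beyond the scatter. Within the data shown here, the one measured step that changes a single place is a number 11 percentage points lower from compound 1 to compound 3 (beyond the scatter), a modest drop for hydrogen in place of methyl on an aromatic nitrogen. Compound 4 `Cn1ccc(-c2ccccc2NCC2=NCCN2)n1` has not been measured yet; it differs from compound 3 by 1-methyl-1H-pyrazol-3-yl in place of 3-methyl-1H-1,2,4-triazol-5-yl on an aromatic carbon. Among the measured compounds shown here, that measured step bears on it only partly: compound 4 again carries a methyl on an aromatic nitrogen, as compound 1 and compound 2 do, but the ring itself also changes, and for that no measured step exists. A modest rise back toward the other two compounds is therefore expected, a number 10 percentage points higher from compound 3 to compound 4 (within the scatter). In this assay compound 4 is estimated at 97%, with a range from 85% to 110%.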

Compound 4, largest response reached (reported as maximal response), in percent of the reference or control that the assay uses: 116%
The estimate for compound 4 lay 19 percentage points below the measured number; the whole stated range lies below it.
By their numbers in this assay, from the lowest: compound 3; then compounds 1, 2 and 4 (each within the scatter of the next, the first and the last beyond it).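

Replacing the whole five-membered ring on this aromatic carbon gives a number 29 percentage points higher from compound 3 to compound 4 (beyond the scatter) in this assay, so the response at this position depends on the ring itself, not only on the small group on a ring nitrogen changed in the earlier step, a number 11 percentage points lower from compound 1 to compound 3 (beyond the scatter). The entering 1-methyl-1H-pyrazol-3-yl has 2 hetero atoms and 0 hydrogen-bond donors, whereas the departing 3-methyl-1H-1,2,4-triazol-5-yl has 3 hetero atoms and 1 hydrogen-bond donor, so several features change in this one step and it cannot be credited to any single one. No measurement at hand explains the rise.

From the compounds shown here alone, it remains open whether the methyl on the ring nitrogen or the change in ring atoms matters more. A pyrazole without that methyl, or with an ethyl in its place, would help separate the two, and a six-membered pyridine ring would test whether a five-membered ring is needed at all.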